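This account rests on a few compounds, and the source may have more. Where it says the series, first, only, none or still open, it means among the compounds named here.

Of the compounds shown here, three of one shared core have been measured. Compound 1 `COc1ccc(C2=C(c3ccc(SC)cc3)CC3CCCN3C2=O)cc1O` carries a hydroxy group on an aromatic carbon, and in a functional assay on DU-145 cells (Homo sapiens) for cytotoxicity (a higher number here means a weaker inhibitor of growth, a lower number a stronger inhibitor of growth), compound 1 gives 6000 nM. Compound 2 `COc1ccc(C2=C(c3ccc(SC)cc3)CC3CCCN3C2=O)cc1C` has a methyl in place of that hydroxy, and in this assay compound 2 gives 900 nM. Compound 3 `CSc1ccc(C2=C(c3ccc(OCC4CO4)cc3)C(=O)N3CCCC3C2)cc1` alters a different part of the molecule, and in this assay compound 3 gives 500 nM. On these numbers compound 2 stands second highest of three: its number lies within the scatter of compound 3, while compound 1 stands well above it, with a 6.7-fold lower number from compound 1 to compound 2 (0.82 log units; beyond the scatter).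

Compound 4 `CSc1ccc(C2=C(c3ccc(C)cc3)C(=O)N3CCCC3C2)cc1` is the unmeasured member. Its change from compound 2 is 4-methylphenyl in place of 4-methoxy-3-methylphenyl on a double-bonded ring carbon.

For the measured compounds named here, only one measured step touches the same aromatic ring, and it swapped a hydroxy for a methyl rather than removing a methoxy and a methyl together, so it bears on the new change only loosely; that step, a 6.7-fold lower number from compound 1 to compound 2 (0.82 log units; beyond the scatter), was modest. Going by the values given here, no measured pair shows what taking away the methoxy does. The expectation is therefore a small step in this assay, likely toward a somewhat higher number for compound 4, with a 1.7-fold higher number from compound 2 to compound 4 (0.22 log units; within the scatter). Compound 4 is estimated at 1500 nM, within a range from 400 nM to 6000 nM.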

Compound 4, concentration for 50% growth inhibition: 600 nM
Compound 4: the middle estimate sits 2.5-fold (0.40 log units) above what was measured; the measured number falls inside the stated range.
By their numbers in this assay, from the lowest: compounds 3, 4 and 2 (each within the scatter of the next); then compound 1.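

In this assay, the ring on the double-bonded ring carbon can lose its methoxy group and have its methyl placed differently, giving 4-methylphenyl, with no change that stands out from the scatter (a 1.5-fold lower number from compound 2 to compound 4 (0.18 log units; within the scatter)). The simple methyl on that aromatic carbon also matches the (oxiran-2-yl)methoxy group of compound 3 within the scatter (a 1.2-fold higher number from compound 3 to compound 4 (0.08 log units; within the scatter)), so among these compounds that longer group is not required to reach this level of growth inhibition. The 3-hydroxy-4-methoxyphenyl group of compound 1 is the one that stands apart (a 10-fold lower number from compound 1 to compound 4 (1.00 log units; beyond the scatter)), which suggests that, of the groups seen here, the ring carrying a hydroxy is the poor one, rather than any ring lacking a methoxy.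

On these data alone, the methoxy and the methyl changed together between compound 2 and compound 4, so their separate contributions remain unknown, as does the outcome with an amine or a carboxylic acid on this ring. Nothing available explains any of these steps.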